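A few compounds are considered here, and "the series" means these few. Any claim that something is new, unique, unknown or untested is made for them only; others in the source may bear on it.

Compound 3 `CNC(=O)COc1ccncc1-c1ccc2ccccc2c1` shares its core with compound 1 `O=C(O)/C=C/c1ccncc1-c1ccc2ccccc2c1` and compound 2 `O=C(/C=C/c1ccncc1-c1ccc2ccccc2c1)NC1CC1`, which carry, in place of its side chain, an acid and a cyclopropylamide. In an assay on a protein complex for inhibition of CDK8/Cyclin C (Homo sapiens), with a stated time of 1 h (a lower number here means a stronger inhibitor, a higher number a weaker inhibitor), compound 1 gives 5 nM and compound 2 gives 40.1 nM; the only step among these, an 8.0-fold higher number from compound 1 to compound 2 (0.90 log units; beyond the scatter), shows that swapping the acid for an amide costs activity. For compound 3 the entry in this assay reads "not determined" (no result reported), so no number places it among its neighbours. Compound 4 `COC(=O)CCc1ccncc1-c1ccc2ccccc2c1` is reached from compound 3 by 2-(methoxycarbonyl)ethyl in place of (methylcarbamoyl)methoxy on an aromatic carbon. Within the data shown here, no measured step covers this change directly; the step from compound 1 to compound 2 only suggests that changes at the end of the side chain can shift the result by a modest amount. Because compound 1 gives 5 nM and compound 2 gives 40.1 nM, compound 4 is expected to land in a similar region, with wide uncertainty, at an estimated 60 nM in this assay, within the range 8 nM to 500 nM.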

Compound 4, half-maximal inhibitory concentration: 259 nM
Compound 4: middle estimate off by 4.3-fold (0.64 log units), on the low side, within the range that was stated.
By their numbers in this assay, from the lowest: compound 1; then compound 2; then compound 4.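

In this assay, among these compounds, 2-(methoxycarbonyl)ethyl in place of 2-carboxyethenyl gives a 52-fold higher number from compound 1 to compound 4 (1.71 log units; beyond the scatter), the only step so far that counts as large. 2-(Methoxycarbonyl)ethyl in place of 2-(cyclopropylcarbamoyl)ethenyl gives a 6.5-fold higher number from compound 2 to compound 4 (0.81 log units; beyond the scatter), so the side chain on this aromatic carbon, ortho to a large group and opposite the ring nitrogen, can shift the result well beyond the scatter in more than one comparison. All three steps among these compounds lie beyond the scatter, which makes compound 4 the weakest of the three with a number.

Going by these compounds, both new steps change the ethenyl link and the end group together, so the share of each stays open, and a 2-carboxyethyl chain, which pairs the acid with the ethyl link, would help to separate them. Nothing available here explains why these differences arise.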